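A few compounds are considered here, and "the series" means these few. Any claim that something is new, unique, unknown or untested is made for them only; others in the source may bear on it.

Measured so far, in a toxicity assay on MCF-10A cells (Homo sapiens) for cytotoxicity, read by MTT assay, with a stated time of 48 h; a higher number here means a weaker inhibitor, a lower number a stronger inhibitor:
Compound 1 `O=C(/C=C/c1ccc2c(c1)B(O)OC2)c1ccc(-c2ccccc2)cc1` gives 20700 nM.
Compound 2 `O=C(/C=C/c1ccc2c(c1)B(O)OC2)c1ccc(Cl)cc1` gives 12100 nM.
Compound 3 `Cc1ccc(C(=O)/C=C/c2ccc3c(c2)B(O)OC3)cc1` gives 8300 nM.

Compound 1 stands at the highest number of the three in this assay. The nearest is compound 2: a 1.7-fold lower number from compound 1 to compound 2 (0.23 log units; within the scatter). The furthest is compound 3: a 2.5-fold lower number from compound 1 to compound 3 (0.40 log units; beyond the scatter). Between the other two, a 1.5-fold lower number from compound 2 to compound 3 (0.16 log units; within the scatter).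

Compound 4 `CSc1ccc(C(=O)/C=C/c2ccc3c(c2)B(O)OC3)cc1` differs from compound 1 in one place: methylsulfanyl in place of phenyl on an aromatic carbon. The two measured steps that bear on this both replace the phenyl on that aromatic carbon with a group that has no ring, and both lowered the number, one within the scatter and one modestly beyond it. A step of similar size, downward, is therefore expected here. Compound 4 is estimated at 10000 nM, with a range of 5000 nM to 22000 nM, which means an expected 2.1-fold lower number from compound 1 to compound 4 (0.32 log units; beyond the scatter).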

Compound 4, half-maximal inhibitory concentration: 7400 nM
Compound 4: the middle estimate sits 1.4-fold (0.13 log units) above what was measured; measured number inside the range.
By their numbers in this assay, from the lowest: compounds 4, 3, 2 and 1 (each within the scatter of the next, the first and the last beyond it).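

Methylsulfanyl, a third group without a ring, also replaces phenyl with a drop in this assay: a 2.8-fold lower number from compound 1 to compound 4 (0.45 log units; beyond the scatter), although the chloro step from compound 1 stayed within the scatter. The three ring-free groups cannot be separated, given a 1.1-fold lower number from compound 3 to compound 4 (0.05 log units; within the scatter) and a 1.6-fold lower number from compound 2 to compound 4 (0.21 log units; within the scatter), so sulfur adds no visible change over methyl or chloro here. Nothing available explains these steps.

From the compounds shown here alone, whether an amine or a carboxylic acid on this aromatic carbon would behave like these three groups remains open. So does the effect of a longer chain.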